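The source may report more compounds than this note shows. Statements on the series, on what has been measured and on what is new or still open speak of the compounds shown alone.

Notes on the series. Among the compounds with values here, the shared core is the one seen in compound 1 `O=C(C1CCCO1)N1CCc2nc(C#Cc3ccccc3)sc2C1`, which in an assay on HEK293 cells for positive allosteric modulation of metabotropic glutamate receptor 5 (Homo sapiens), read by FLIPR, with a stated time of 1 h (on this read-out lower numbers stand for an effect already at smaller amounts and higher numbers for an effect only at larger amounts of compound), gives 790 nM. Within the data shown here, compound 2 `Cc1nc(C(=O)N2CCc3nc(C#Cc4ccccc4)sc3C2)cs1` differs only on the carbonyl carbon and in this assay gives 220 nM; the change a 3.6-fold lower number from compound 1 to compound 2 (0.56 log units; beyond the scatter) is the only measured step so far. On the numbers shown, compound 2 therefore has the lowest number of the two, with compound 1 the nearest and the gap between them beyond the scatter.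

Compound 3 `O=C(N1CCC(F)CC1)N1CCc2nc(C#Cc3ccccc3)sc2C1` keeps the core and again alters the group on the carbonyl carbon: 4-fluoropiperidin-1-yl in place of 2-methyl-1,3-thiazol-4-yl on a carbonyl carbon. Among the measured compounds shown here, the one step that bears on it, the step from compound 1 to compound 2, was of modest size and shows that an exchange at this position shifts the read-out by a modest amount. A step of that order, in the direction of a higher number, is expected from compound 2 to compound 3, a 2.0-fold higher number from compound 2 to compound 3 (0.31 log units; beyond the scatter). Compound 3 is thus estimated at 450 nM in this assay, within 140 nM to 1500 nM.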

Compound 3, half-maximal effective concentration: 74 nM
Estimate against measurement, compound 3: 6.1-fold (0.78 log units) above; measured number outside the range, below it.
By their numbers in this assay, from the lowest: compound 3; then compound 2; then compound 1.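

In this assay, 4-fluoropiperidin-1-yl on the carbonyl carbon gives a lower number than either earlier group: against 2-methyl-1,3-thiazol-4-yl (a 3.0-fold lower number from compound 2 to compound 3 (0.47 log units; beyond the scatter)) and against oxolan-2-yl (an 11-fold lower number from compound 1 to compound 3 (1.03 log units; beyond the scatter)). The span at this one position is therefore large, and with non-aromatic rings at both ends of the order and the aromatic ring in the middle, aromatic against non-aromatic does not sort these three compounds. Nothing measured here accounts for the lower number of compound 3.

The compounds shown leave open what the fluorine itself contributes, a question that plain piperidin-1-yl would address directly. They also leave open whether attachment through the ring nitrogen matters, which a piperidin-4-yl group, joined through ring carbon, would test.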